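The source may hold more compounds than are shown below. What is called first, only, known or untested is meant among the compounds shown, and "the series" means these compounds.

Measured compounds in an ADME assay on RAW264.7 cells (Mus musculus) for cytotoxicity, read by MTT assay, with a stated time of 24 h, tested at 5 ug/mL; a higher number here means a weaker effect of the compound at the concentration tested, a lower number a stronger effect:

compound 1, `COc1cc(/C=C/C(=O)c2cccc(O)c2)ccc1O`: 63.8%
compound 2, `COc1ccc(C(=O)/C=C/c2ccc(OC)c(OC)c2)c(O)c1`: 73.9%
compound 3, `COc1ccc(C(=O)/C=C/c2cccc(OC)c2OC)c(O)c1`: 69.7%

Compound 1 gives the lowest of the three numbers in this assay. Its nearest neighbour is compound 3, whose number sits higher by an amount within the usual scatter, so no order can be read between the two. Compound 2 lies furthest away, its number higher by an amount beyond the scatter.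

The next compound in the series is compound 4, `COc1ccc(/C=C/C(=O)c2cccc(O)c2)cc1OC`. Its difference from compound 1 is methyl in place of hydrogen on an oxygen on an aromatic ring. Among the measured compounds shown here, no pair of measured compounds differs in only this one place, so the size of the step has to be estimated rather than read from the data. Compound 2 carries the same methoxy pair and gives 73.9%, which is the only hint available; it also differs elsewhere, so it is a weak guide.

The step from compound 1 to compound 4 in this assay is expected to be modest and upward, a number 6.2 percentage points higher from compound 1 to compound 4 (within the scatter), with a real chance it stays within the scatter. Compound 4 is expected to give about 70%, within a range from 58% to 82%.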

Compound 4, a percentage reported as activity, at one concentration (the size of the read-out at that concentration, not a potency): 83.8%
Estimate against measurement, compound 4: 13.8 percentage points below; the measured number lies above the stated range.
By their numbers in this assay, from the lowest: compounds 1, 3, 2 and 4 (each within the scatter of the next, the first and the last beyond it).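

In this assay hydroxy to methoxy gives a number 20 percentage points higher from compound 1 to compound 4 (beyond the scatter) and so a weaker effect at the concentration tested. Among the compounds shown here, this is the first pair that differs in one place only, and it shows that methyl in place of hydrogen on this oxygen is enough on its own to move the read-out beyond the scatter. Nothing measured here accounts for the step, so its cause stays unknown.

From the compounds shown here alone, it remains open whether the step follows from the loss of the hydrogen or from the arrival of the methyl; an ethyl group or a longer chain on the same oxygen, or an acetyl group there, would help to tell these apart. Going by these compounds, whether the same change gives a step of similar size elsewhere on the core of compound 1 also remains open.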